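The source may hold more compounds than are shown below. What is called first, only, known or untested is meant among the compounds shown, and "the series" means these compounds.

In a functional assay on OVCAR-8 cells (Homo sapiens) for antiproliferative activity (on this read-out lower numbers stand for stronger inhibition and higher numbers for weaker inhibition), compound 1 (`Cn1ncc(Cl)c1-c1cc(C(=O)N[C@@H]2CN[C@H](CC(O)CO)C[C@H]2c2ccc(Cl)c(Cl)c2)oc1Cl`) gives 1610 nM, while compound 2 (`Cn1ncc(Cl)c1-c1cc(C(=O)N[C@@H]2CN[C@H](CCN3CCC(O)CC3)C[C@H]2c2ccc(Cl)c(Cl)c2)oc1Cl`) gives 15900 nM, the higher of the two numbers. Compound 3 (`Cn1ncc(Cl)c1-c1cc(C(=O)N[C@@H]2CN[C@H](CCCO)C[C@H]2c2ccc(Cl)c(Cl)c2)oc1Cl`) is not yet measured. It differs from compound 2 by hydroxymethyl in place of 4-hydroxypiperidin-1-yl on a saturated chain carbon, two bonds along the chain from a saturated ring carbon, with hydroxymethyl in place of 4-hydroxypiperidin-1-yl. Within the data shown here, the only measured step bearing on this change is a 9.9-fold higher number from compound 1 to compound 2 (0.99 log units; beyond the scatter), which brought in that same 4-hydroxypiperidin-1-yl group. Losing the group is therefore expected to give a step of similar size toward lower numbers in this assay. The expected step is a 7.2-fold lower number from compound 2 to compound 3 (0.86 log units; beyond the scatter). For compound 3, the estimated value is 2200 nM, within an expected range of 800 nM to 6500 nM.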

Compound 3, half-maximal inhibitory concentration: 600 nM
For compound 3 the middle estimate is 3.7-fold (0.56 log units) above the measured one; measured number outside the range, below it.
By their numbers in this assay, from the lowest: compound 3; then compound 1; then compound 2.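

In this assay, the 4-hydroxypiperidin-1-yl group proves to be a clear liability at this position, as its replacement by hydroxymethyl gives a 27-fold lower number from compound 2 to compound 3 (1.42 log units; beyond the scatter). The second hydroxy of compound 1 is not required either: hydrogen in its place gives a 2.7-fold lower number from compound 1 to compound 3 (0.43 log units; beyond the scatter), leaving the 3-hydroxypropyl chain of compound 3 lowest of the three. Nothing available explains either step. Still open, on these data alone, is whether the remaining hydroxy matters at all, and how a plain propyl chain, an amine in place of that hydroxy, or a longer chain would read.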